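Removing the cyclohexyl from the ring nitrogen of compound 2

A few compounds are considered here, and "the series" means these few. Any claim that something is new, unique, unknown or untested is made for them only; others in the source may bear on it.

Of the compounds shown here, three have been measured in a functional assay on HeLa cells (Homo sapiens) for antiproliferative activity, read by MTT assay, with a stated time of 72 h; on this read-out lower numbers stand for stronger inhibition and higher numbers for weaker inhibition. Compound 1 `O=C1COc2ccc(-c3cnc4ccccc4c3)cc2N1c1ccccc1` reaches only the limit of the assay, > 40000 nM, which is a limit and not a number. Compound 2 `O=C1COc2ccc(-c3cnc(Cl)c(NS(=O)(=O)c4ccc(F)cc4)c3)cc2N1C1CCCCC1` gives 14300 nM in this assay, the higher of the two numbers available. Among the compounds with values here, compound 3 `COc1ncc(-c2ccc3c(c2)N(C2CCCCC2)C(=O)CO3)cc1NS(=O)(=O)c1ccc(F)cc1` gives 6100 nM in this assay; the single measured step, a 2.3-fold lower number from compound 2 to compound 3 (0.37 log units; beyond the scatter), concerns methoxy in place of chloro on an aromatic carbon and nothing else.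

Compound 4 `O=C1COc2ccc(-c3cnc(Cl)c(NS(=O)(=O)c4ccc(F)cc4)c3)cc2N1` differs from compound 2 in one place: hydrogen in place of cyclohexyl on an amide-type nitrogen in a ring. Within the data shown here, no measured step touches the amide-type nitrogen in the ring, so the size of this change cannot be read from the measured pair; the expectation rests on compound 2 alone and must be wide. Compound 4 is expected to give about 25000 nM in this assay, within a range from 8000 nM to 60000 nM. The estimated step is a 1.7-fold higher number from compound 2 to compound 4 (0.24 log units; within the scatter), and a limit, as with compound 1, remains a real possibility.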

Compound 4, half-maximal inhibitory concentration: 15600 nM
The estimate for compound 4 lay 1.6-fold (0.20 log units) above the measured number; the range from low to high includes it.
By their numbers in this assay, from the lowest: compound 3; then compounds 2 and 4 (each within the scatter of the next). At a limit, above all of these: compound 1.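

In this assay, the change from cyclohexyl to hydrogen on the amide-type nitrogen in the ring leaves the read-out within the scatter: a 1.1-fold higher number from compound 2 to compound 4 (0.04 log units; within the scatter). At this position, the two compounds therefore give no sign that the cyclohexyl contributes to the antiproliferative activity, and this holds only for the chloro compounds 2 and 4. Compound 1 is the only compound shown at a limit, which is not a number, so it cannot be set against this step: the limit of > 40000 nM in this assay, at which 1 of the 4 values shown sits.

On these data alone, whether a methyl, a longer chain ending in an amine, or a carboxylic acid on this nitrogen would move the number beyond the scatter remains open. Also open, as far as these compounds go, is whether the same change would stay as flat with the methoxy of compound 3 in place of the chloro.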